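Benzamido in Place of Allyloxy: An Expected Cytotoxicity

A few compounds are considered here, and "the series" means these few. Any claim that something is new, unique, unknown or untested is made for them only; others in the source may bear on it.

Compound 1 `COc1ccc(C2=C(c3cc(OC)c(OC)c(OC)c3)C(=O)C(OC(C)=O)C2)cc1Cl` was tested in an ADME assay on L132 cells (Homo sapiens) for cytotoxicity, read by MTT assay, with a stated time of 72 h; a higher number here means a weaker inhibitor, a lower number a stronger inhibitor; for compound 1 the reported value is a limit of the assay, < 1 ug/mL, and (the limit of < 1 ug/mL in this assay, at which 1 of the 3 values shown sits). Compound 2 `COc1cc(C2=C(c3cc(C)c(OC)c(C)c3)C(O)CC2=O)cc(OC)c1OC` also reaches only a limit there, > 100 ug/mL. Compound 3 `C=CCOc1cc(C2=C(c3cc(OC)c(OC)c(OC)c3)C(=O)C(O)C2)ccc1OC` stands at the same end of the numbers shown: in this assay compound 3 gives a limit of the assay, > 100 ug/mL, and (the limit of > 100 ug/mL in this assay, at which 2 of the 3 values shown sit). Among the compounds with values here, no measured pair differing in one place connects compound 3 to another compound. Compound 4 `COc1ccc(C2=C(c3cc(OC)c(OC)c(OC)c3)C(=O)C(O)C2)cc1NC(=O)c1ccccc1` differs from compound 3 by benzamido in place of allyloxy on an aromatic carbon. Within the data shown here, with no measured step covering this change, the shift expected in this assay is small, an at least 1.2-fold lower number from compound 3 to compound 4 (0.09 log units; that floor lies within the scatter), and a limit may again be reported. Compound 4 is therefore expected to give 80 ug/mL, between 15 ug/mL and 100 ug/mL.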

Compound 4, half-maximal inhibitory concentration: > 100 ug/mL
Compound 4 was reported as a limit (the forecaster's own chance of this, stated with the estimate: 55%); middle value at least 1.2-fold (0.09 log units) from the limit.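

Within the data shown here, compound 3 and compound 4 both reach only a limit in this assay, and no step between them can be read. The compounds shown leave open whether benzamido in place of allyloxy changes the cytotoxicity at all.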